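This account rests on a few compounds, and the source may have more. Where it says the series, first, only, none or still open, it means among the compounds named here.

Compound 1 `O=C1NC(=O)/C(=C\c2ccc(OCC(=O)N3N=C(c4ccccc4)CC3c3ccc(F)cc3)cc2)S1` in an assay on cells for inhibition of histone deacetylase 8 (Homo sapiens), read by fluorescence, with a stated time of 30 min (on this read-out lower numbers stand for stronger inhibition and higher numbers for weaker inhibition), gives 26000 nM. Compound 2 `Cc1ccc(C2CC(c3ccccc3)=NN2C(=O)COc2ccc(/C=C3/SC(=O)NC3=O)cc2)cc1` in this assay gives 31000 nM, a step of a 1.2-fold higher number from compound 1 to compound 2 (0.08 log units; within the scatter) for the change (methyl in place of fluoro on an aromatic carbon). Compound 3 `O=C1NC(=O)/C(=C\c2ccc(OCC(=O)N3N=C(c4ccc(F)cc4F)CC3c3ccc(F)cc3)cc2)S1` carries a different core, told by 2,4-difluorophenyl in place of phenyl on a carbon with a double bond to nitrogen. For compound 3 this assay reports only a limit, > 50000 nM. The step of an at least 1.9-fold higher number from compound 1 to compound 3 (0.28 log units; that floor lies within the scatter) therefore has a floor only.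

Compound 4 `Cc1ccc(C2CC(c3ccc(F)cc3F)=NN2C(=O)COc2ccc(/C=C3/SC(=O)NC3=O)cc2)cc1` is not yet measured. It differs from compound 3 by methyl in place of fluoro on an aromatic carbon, the same change as made from compound 1 to compound 2, with the place described in identical words. That earlier step stayed within the scatter, and compound 3 already sits at the limit of > 50000 nM in this assay, at which 1 of the 3 values shown sits, so a value at or near the limit is expected for compound 4, with an estimated step that the limit leaves unreadable from compound 3 to compound 4. Compound 4 is estimated at 55000 nM, in the range 25000 nM to 150000 nM.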

Compound 4, half-maximal inhibitory concentration: > 50000 nM
Compound 4 gave a limit, no number; the forecaster's own chance of this, stated with the estimate: 70%; the middle value is on the limit's open side.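

The result for compound 4 in this assay is a limit, > 50000 nM, and compound 3 also has only a limit, so the step between them cannot be read. Methyl in place of fluoro can therefore be read only on the core of compound 1, where it stays within the scatter, and nothing shows whether this carries over to the core of compound 3. On the core of compound 2, 2,4-difluorophenyl in place of phenyl gives an at least 1.6-fold higher number from compound 2 to compound 4 (0.20 log units; that floor lies within the scatter), a floor only, and the comparison with the earlier step reads: the same change on two cores in this assay, an at least 1.9-fold higher number (0.28 log units; that floor lies within the scatter) from compound 1 to compound 3 and an at least 1.6-fold higher number (0.20 log units; that floor lies within the scatter) from compound 2 to compound 4; the limit leaves it open whether they differ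

Still open, on these data alone, is what numbers compound 3 and compound 4 would give if they could be read. Also open, as far as these compounds go, is how an amine or a carboxylic acid would read in this assay in place of the fluoro or methyl group.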